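The source may report more compounds than this note shows. Statements on the series, on what has been measured and on what is new or still open speak of the compounds shown alone.

In a functional assay on the whole organism with Rattus norvegicus as the target (on this read-out lower numbers stand for an effect already at smaller amounts and higher numbers for an effect only at larger amounts of compound), compound 1 (`Oc1nc(-c2ccccc2)ncc1-c1nn[nH]n1`) gives 100 mg/kg and compound 2 (`COc1ccccc1-c1ncc(-c2nn[nH]n2)c(O)n1`) gives 0.1 mg/kg as the lower of the two numbers. Compound 3 (`CCOc1ccccc1-c1ncc(-c2nn[nH]n2)c(O)n1`) carries methyl in place of hydrogen on a saturated chain carbon bound to an oxygen on an aromatic ring, turning methoxy to ethoxy (methyl in place of hydrogen on a saturated chain carbon bound to an oxygen on an aromatic ring). Among the measured compounds shown here, the one measured step bearing on this, methoxy in place of hydrogen on an aromatic carbon, is large (a 1000-fold lower number from compound 1 to compound 2 (3.00 log units; beyond the scatter)), but no change within the chain has been measured. A far smaller step is expected in this assay, with none beyond the scatter and no direction foreseen (no change at the digits printed from compound 2 to compound 3 (within the scatter) expected). For compound 3 the estimated value is 0.1 mg/kg (expected range 0.02 mg/kg to 0.5 mg/kg).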

Compound 3, dose for 50% inhibition: 0.09 mg/kg
Estimate against measurement, compound 3: 1.1-fold (0.05 log units) above; measured number inside the range.
By their numbers in this assay, from the lowest: compounds 3 and 2 (each within the scatter of the next); then compound 1.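

Lengthening methoxy to ethoxy in this assay gives a step within the scatter (a 1.1-fold lower number from compound 2 to compound 3 (0.05 log units; within the scatter)), so the saturated chain carbon bound to an oxygen on an aromatic ring takes a methyl with no readable change. The large step from the core of compound 1 remains with ethoxy (a 1100-fold lower number from compound 1 to compound 3 (3.05 log units; beyond the scatter)), which shows that it does not depend on methoxy alone. No measurement in hand bears on the reason for either step.

As far as these compounds go, whether a longer chain such as propoxy leaves the number unchanged remains open. So does the effect of an amine or a carboxylic acid in place of the ethoxy group.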